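A few compounds are considered here, and "the series" means these few. Any claim that something is new, unique, unknown or untested is made for them only; others in the source may bear on it.

Compound 1, with structure `COC(=O)CCn1cc(C(=O)C(=O)Nc2ccc(OC)nc2)c2ccccc21`, is the starting point of this account. In a functional assay on FaDu cells (Homo sapiens) for cytotoxicity, read by MTT assay, with a stated time of 72 h (on this read-out higher numbers stand for lower toxicity in this test and lower numbers for higher toxicity in this test), compound 1 gives 168 nM, the lowest of the two plain numbers reported in that test. Compound 3, with structure `CCn1cc(C(=O)C(=O)Nc2ccnc(OC)c2)c2ccccc21`, gives 4180 nM in this assay, a gap to compound 1 that lies beyond the scatter. Compound 2, with structure `CCOC(=O)COc1ccc(NC(=O)C(=O)c2cn(CCOC)c3ccccc23)cn1`, is reported in this assay only as a limit of > 10000 nM, one of the cases described by the limit of > 10000 nM in this assay, at which 1 of the 3 values shown sits, and no number is known for it. Within the data shown here, no two of the measured compounds differ in only one place, so no single measured step can be followed among them.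

Compound 4, with structure `COc1ccc(NC(=O)C(=O)c2cn(CC3CCO3)c3ccccc23)cn1`, has not yet been measured in this assay. It differs from compound 1 by the change (oxetan-2-yl in place of (methoxycarbonyl)methyl on a saturated chain carbon bound to an aromatic nitrogen). Among the measured compounds shown here, since no measured step connects this kind of change to a value in this assay, the direction of the step is uncertain, and a change of modest size in either direction is expected, most likely a loss. The estimate for compound 4 in this assay is 400 nM, with a range from 120 nM to 1500 nM. The expected step from compound 1 to compound 4 is therefore a 2.4-fold higher number from compound 1 to compound 4 (0.38 log units; beyond the scatter).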

Compound 4, concentration lethal to 50% of the cells: 686 nM
The estimate for compound 4 lay 1.7-fold (0.23 log units) below the measured number; the range from low to high includes it.
By their numbers in this assay, from the lowest: compound 1; then compound 4; then compound 3. At a limit, above all of these: compound 2.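

Among these compounds, the change gives the first measured step at this place, on a saturated chain carbon bound to an aromatic nitrogen: in this assay there is a 4.1-fold higher number from compound 1 to compound 4 (0.61 log units; beyond the scatter). The step is modest but lies beyond the scatter, so replacing (methoxycarbonyl)methyl with oxetan-2-yl makes a readable difference on the otherwise unchanged core, and the number moves towards lower toxicity in this test. At the same time, the ester is not required for a plain number in this test, since compound 4 has no ester and no carbonyl in this group, yet gives 686 nM rather than a limit, although nothing shown gives a cause for the size or direction of this step.

Going by these compounds, this single step cannot separate the loss of the methyl ester from the arrival of the four-membered ring, and the effect of either alone remains open. Also open, on these data alone, is how a carboxylic acid, an amine or a longer chain at this place would compare in this assay with the 2-(methoxycarbonyl)ethyl and (oxetan-2-yl)methyl groups of the two compounds.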